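The compounds below may be only part of what the source reports. "The series", "measured", "known", "first", "only" and "open" are said of these compounds alone.

Measured compounds:
- compound 1, `CCN(CC)c1nc(Nc2cccc(F)c2)nc(OC(C(F)(F)F)C(F)(F)F)n1`, in an assay on cells for activation of Cystic fibrosis transmembrane conductance regulator (Homo sapiens), read by fluorescence, with stated times of 10 min and 12 s (on this read-out lower numbers stand for an effect already at smaller amounts and higher numbers for an effect only at larger amounts of compound), gives 140 nM
- compound 2, `CCN(CC)c1nc(Nc2ccc(C(=O)O)cc2)nc(OC(C(F)(F)F)C(F)(F)F)n1`, in this assay gives 900 nM
- compound 3, `CCN(CC)c1nc(Nc2ccc3cn[nH]c3c2)nc(OC(C(F)(F)F)C(F)(F)F)n1`, in this assay gives 900 nM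

Compound 2 stands level with compound 3 at the digits shown, and these two together give the highest numbers of the three; compound 1 lies furthest away, a step of a 6.4-fold higher number from compound 1 to compound 2 (0.81 log units; beyond the scatter) separating them. Compound 4, `CCN(CC)c1nc(Nc2ccc3ncoc3c2)nc(OC(C(F)(F)F)C(F)(F)F)n1`, has not been measured in this assay. It differs from compound 2 in one place: 1,3-benzoxazol-6-yl in place of 4-carboxyphenyl on a nitrogen on an aromatic ring.

Among the measured compounds shown here, two measured steps bear on this change. The step of no change at the digits printed from compound 2 to compound 3 (within the scatter) exchanged the same 4-carboxyphenyl for another fused bicyclic aromatic group, 1H-indazol-6-yl, and gave no change at the digits shown. The steps of a 6.4-fold higher number from compound 1 to compound 2 (0.81 log units; beyond the scatter) and a 6.4-fold higher number from compound 1 to compound 3 (0.81 log units; beyond the scatter) show that both the carboxyphenyl and the indazolyl groups sit at the same higher level than the 3-fluorophenyl of compound 1. Since the 1,3-benzoxazol-6-yl group of compound 4 is, like the indazolyl group, a fused bicyclic aromatic group on the same nitrogen, compound 4 is expected to land near compound 3 and compound 2, that is, no step beyond the scatter is expected in this assay. Compound 4 is therefore estimated at 800 nM, with a range from 250 nM to 2500 nM, which means an expected step of a 1.1-fold lower number from compound 2 to compound 4 (0.05 log units; within the scatter).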

Compound 4, half-maximal effective concentration: 150 nM
Beside the measured number, compound 4's estimate is 5.3-fold (0.73 log units) above it, outside the stated range (below it).
By their numbers in this assay, from the lowest: compounds 1 and 4 (each within the scatter of the next); then compounds 2 and 3 (each within the scatter of the next).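

In this assay, the place on a nitrogen on an aromatic ring now separates two fused ring groups: the 1,3-benzoxazol-6-yl group gives a 6.0-fold lower number from compound 3 to compound 4 (0.78 log units; beyond the scatter), and the same group in place of 4-carboxyphenyl gives a 6.0-fold lower number from compound 2 to compound 4 (0.78 log units; beyond the scatter), so having two fused aromatic rings does not by itself put a compound at the higher number shared by compound 2 and compound 3. A fused group also need not give a higher number than a single ring here, since the exchange for 3-fluorophenyl gives a 1.1-fold higher number from compound 1 to compound 4 (0.03 log units; within the scatter). Nothing available here accounts for the difference between the 1,3-benzoxazol-6-yl group and the other two groups at this place.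

The compounds shown leave open which part of the 1,3-benzoxazol-6-yl group matters, for instance whether a sulfur atom in place of its ring oxygen would keep the number near that of compound 4. They also leave open whether a methyl ester or a primary amide in place of the carboxylic acid of compound 2 would move its number in the same direction.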